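The compounds below may be only part of what the source reports. "The series", "measured", "known", "first", "only" and "open" are said of these compounds alone.

Among the compounds with values here, in a functional assay on HeLa cells (Homo sapiens) for inhibition, read by WST assay, with stated times of 72 h and 2 h (on this read-out higher numbers stand for weaker inhibition and lower numbers for stronger inhibition), compound 1 (`OC(c1cccs1)c1cc2ccccc2nc1Cl`) gives 17500 nM, the only number available so far. Compound 2 (`Cc1ccc(-c2cc(COC(c3cccs3)c3cc4ccccc4nc3Cl)on2)cc1`) carries a substituent on the oxygen that is a free hydroxy in compound 1. Compound 2 gives "not active" (no number reported), so no number was reported for it. Within the data shown here, compound 1 therefore stands alone on the numeric scale, and no step between measured compounds is available to size the next change. Compound 3 (`Clc1nc2ccccc2cc1C(OCc1ccccc1)c1cccs1`) is still to be measured in this assay. It differs from compound 1 by a single change, hydroxy to benzyloxy, with benzyl in place of hydrogen on an oxygen on a saturated carbon. Among the measured compounds shown here, the only guide is compound 2, also substituted on that oxygen, and its result of "not active" (no number reported) leaves weaker inhibition as the more likely direction. One compound is thin support, so only a small shift is expected, and the estimated 1.4-fold higher number from compound 1 to compound 3 (0.15 log units; within the scatter) may not exceed the usual scatter. For compound 3 the expected value is 25000 nM, with an estimated range from 8000 nM to 80000 nM.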

Compound 3, half-maximal inhibitory concentration: "not active" (no number reported)
The entry for compound 3 holds no number; no gap can be computed for the estimate.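

In this assay, within the data shown here, compound 3 gave no number, like compound 2, so no step from compound 1 can be read and compound 1 stays alone on the numeric scale at 17500 nM here. Nothing in the data bears on this result. The compounds shown leave open how far replacing the hydroxy hydrogen shifts inhibition.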